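Amide variation on the hydroxamate series: compound 4

The source may hold more compounds than are shown below. What is called first, only, known or untested is meant among the compounds shown, and "the series" means these compounds.

Measured so far in an assay on CHO cells for inhibition of bone morphogenetic protein 1 (Homo sapiens), read by fluorescence; on this read-out lower numbers stand for stronger inhibition and higher numbers for weaker inhibition:
compound 1 `O=C(C[C@@H](CCCC1CCCCC1)c1nc(C(=O)NCc2ccccc2)no1)NO`, 57 nM
compound 2 `O=C(C[C@@H](CCCC1CCCCC1)c1nc(C(=O)N2CCCC2)no1)NO`, 43 nM
compound 3 `CN1CCN(CN(C)C(=O)c2noc([C@H](CCCC3CCCCC3)CC(=O)NO)n2)CC1`, 54 nM

Compound 2 holds the lowest of the three numbers, but both other values sit within the scatter of it. Compound 4 `CN(Cc1ccccn1)C(=O)c1noc([C@H](CCCC2CCCCC2)CC(=O)NO)n1` is still unmeasured; it differs from compound 2 in one place: methyl((pyridin-2-yl)methyl)amino in place of pyrrolidin-1-yl on a carbonyl carbon.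

Going by the values given here, the steps that bear on this change are the other amide swaps on the same carbonyl carbon: a 1.3-fold lower number from compound 1 to compound 2 (0.12 log units; within the scatter) and a 1.3-fold higher number from compound 2 to compound 3 (0.10 log units; within the scatter). Neither moved the number beyond the scatter, so in this assay no step beyond the scatter is expected for compound 4 either. The estimate for compound 4 is 50 nM, range 25 nM to 100 nM, meaning an expected step of a 1.2-fold higher number from compound 2 to compound 4 (0.07 log units; within the scatter).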

Compound 4, half-maximal inhibitory concentration: 40 nM
Compound 4: middle estimate off by 1.3-fold (0.10 log units), on the high side, and the stated range covers the measured number.
By their numbers in this assay, from the lowest: compounds 4, 2, 3 and 1 (each within the scatter of the next).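

In this assay, the methyl((pyridin-2-yl)methyl)amino amide brings a six-membered aromatic ring and a hydrogen-bond acceptor onto the carbonyl carbon, yet the swap gives a 1.1-fold lower number from compound 2 to compound 4 (0.03 log units; within the scatter). The comparisons with the other amides, a 1.4-fold lower number from compound 3 to compound 4 (0.13 log units; within the scatter) and a 1.4-fold lower number from compound 1 to compound 4 (0.15 log units; within the scatter), show the same, so all four compounds remain within the scatter of one another. No measurement at hand accounts for this. Still open, going by these compounds, is whether an amide bearing a carboxylic acid or a primary amine would move the number beyond the scatter.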